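One More Methoxy Group: Compound 2 to Compound 4

The compounds below may be only part of what the source reports. "The series", "measured", "known", "first", "only" and "open" are said of these compounds alone.

Compound 1 `COc1cc(-c2cc(/C=C/C(=O)c3ccc(N)cc3)[nH]n2)cc(OC)c1OC`: -93%
Compound 2 `COc1ccc(C(=O)/C=C/c2cc(-c3cc(OC)c(OC)c(OC)c3)n[nH]2)cc1OC`: -94%
Compound 3 `COc1ccc(C(=O)/C=C/c2cc(-c3cc(OC)c(OC)c(OC)c3)n[nH]2)cc1`: -92%

In a functional assay on SF-539 cells (Homo sapiens) for cytotoxicity, read by sulforhodamine B assay, with a stated time of 48 h, tested at 10 uM (on this read-out higher numbers stand for a weaker effect at the one concentration tested and lower numbers for a stronger effect), compound 2 gives -94%, the lowest of the three numbers, though the others sit close: compound 1 gives -93% and compound 3 gives -92%, and the step of a number 2 percentage points higher from compound 2 to compound 3 (within the scatter) lies within the scatter. Compound 4 `COc1cc(C(=O)/C=C/c2cc(-c3cc(OC)c(OC)c(OC)c3)n[nH]2)cc(OC)c1OC` differs from compound 2 by a single change: methoxy in place of hydrogen on an aromatic carbon. Going by the values given here, two measured steps bear on it. The step of a number 2 percentage points higher from compound 2 to compound 3 (within the scatter) removes a methoxy group from the same ring, and the step of a number 1 percentage points lower from compound 1 to compound 2 (within the scatter) swaps the whole ring; neither moved the read-out beyond the scatter. Adding a methoxy group is therefore expected to change little, a step of a number 1 percentage points higher from compound 2 to compound 4 (within the scatter). For compound 4 the estimate is -93%, with a range from -99% to -82%.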

Compound 4, a percentage reported as activity, at one concentration (the size of the read-out at that concentration, not a potency): -80%
For compound 4 the middle estimate is 13 percentage points below the measured one; the whole stated range lies below it.
By their numbers in this assay, from the lowest: compounds 2, 1 and 3 (each within the scatter of the next); then compound 4.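

In this assay, the added methoxy group produces the first step beyond the scatter among these compounds, a number 14 percentage points higher from compound 2 to compound 4 (beyond the scatter), a modest weakening of the effect. Removing a methoxy group from the same ring had stayed within the scatter, so changes on this ring are not all equally silent, and this position, ortho to a methoxy group and meta to a large group, responds to added methoxy. Nothing available accounts for this shift. On these data alone, it remains open whether a hydroxy group, a fluorine atom or an amine at this position would shift the read-out in the same way.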